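A few compounds are considered here, and "the series" means these few. Any claim that something is new, unique, unknown or untested is made for them only; others in the source may bear on it.

Compound 1 `CCOC(=O)Nc1nc(=O)n(C2O[C@H](C(=O)O)[C@@H](O)[C@H]2O)cc1F` gives 0.16 ug/mL 
Compound 2 `C=CCOC(=O)Nc1nc(=O)n(C2O[C@H](C(=O)O)[C@@H](O)[C@H]2O)cc1F` gives 0.008 ug/mL 

Compound 2 holds the lower of these two numbers in a functional assay on SK-OV-3 cells (Homo sapiens) for inhibition (a lower number here means a stronger inhibitor, a higher number a weaker inhibitor), and so is the stronger inhibitor of the pair. Compound 3 `C#CCOC(=O)Nc1nc(=O)n(C2O[C@H](C(=O)O)[C@@H](O)[C@H]2O)cc1F` differs from it by ethynyl in place of vinyl on a saturated chain carbon bound to an oxygen next to a carbonyl group in short, ethynyl in place of vinyl on a saturated chain carbon bound to an oxygen next to a carbonyl group. Among the measured compounds shown here, one measured step bears on this, a 20-fold lower number from compound 1 to compound 2 (1.30 log units; beyond the scatter) and it was large. That step put vinyl in place of methyl, a different swap, so a smaller change is expected here, leaning towards a higher number. The expected size in this assay is a 1.9-fold higher number from compound 2 to compound 3 (0.27 log units; within the scatter) for this swap. Compound 3 is expected at 0.015 ug/mL with 0.004 ug/mL to 0.08 ug/mL as its range.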

Compound 3, half-maximal inhibitory concentration: 0.005 ug/mL
Compound 3: the middle estimate sits 3.0-fold (0.48 log units) above what was measured; low and high end bracket the measured number.
By their numbers in this assay, from the lowest: compounds 3 and 2 (each within the scatter of the next); then compound 1.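

In this assay, ethynyl in place of vinyl gives a 1.6-fold lower number from compound 2 to compound 3 (0.20 log units; within the scatter), so this assay does not separate the double bond from the triple bond at this position. Against the saturated end of compound 1, ethynyl gives a 32-fold lower number from compound 1 to compound 3 (1.51 log units; beyond the scatter), which shows that the large drop is not unique to vinyl. Nothing measured here explains either step.

From the compounds shown here alone, it remains open how a longer chain or a phenyl group would read on a saturated chain carbon bound to an oxygen next to a carbonyl group.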